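The source may hold more compounds than are shown below. What is called first, only, known or untested is meant among the compounds shown, and "the series" means these compounds.

In a functional assay on KOPN-8 cells (Homo sapiens) for antiproliferative activity, with a stated time of 72 h (a higher number here means that more compound is needed for the effect, a lower number that less compound is needed), compound 3 `COc1ccc(-c2cc(=O)c3c(OC)cc(OC)cc3n2S(=O)(=O)c2ccc(F)cc2)cc1` gives only a limit, > 65500 nM. Compound 1 `COc1ccc(-c2cc(=O)c3c(OC)cc(OC)cc3n2Cc2ccccc2)cc1` likewise gives only a limit, > 17300 nM. Compound 2 `COc1ccc(-c2cc(=O)c3c(OC)cc(OC)cc3n2S(=O)(=O)c2ccc(C#N)cc2)cc1` also gives only a limit, > 17200 nM. Every value here is a limit. The steps a step that the two limits leave unreadable from compound 1 to compound 2, a step that the two limits leave unreadable from compound 1 to compound 3 and a step that the two limits leave unreadable from compound 2 to compound 3 cannot be read in size or direction. Compound 4 `COc1ccc(-c2cc(=O)c3c(OC)cc(OC)cc3n2S(=O)(=O)c2ccc(OC)cc2)cc1` differs from compound 3 by methoxy in place of fluoro on an aromatic carbon. Among the compounds with values here, none of the measured steps gives a readable size for a change of this kind, so no shift beyond the scatter can be foreseen. The step of an at least 2.1-fold lower number from compound 3 to compound 4 (0.33 log units; beyond the scatter) is therefore estimated to leave the value near the limit. Compound 4 is expected to give about 30000 nM in this assay, within 10000 nM to 100000 nM, most likely again only as a limit.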

Compound 4, half-maximal effective concentration: > 82700 nM
Compound 4: no number, only a limit (the forecaster's own chance of this, stated with the estimate: 80%); middle value at least 2.7-fold (0.44 log units) from the limit.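

Within the data shown here, compound 1, compound 2, compound 3 and compound 4 all give only limits, so no step from compound 4 to the others can be read. The compounds shown leave open what concentration, if any, produces the effect in this assay.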